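A few compounds are considered here, and "the series" means these few. Any claim that something is new, unique, unknown or untested is made for them only; others in the source may bear on it.

In an in vivo ADME assay on the whole organism (strain Mongrel) for pharmacokinetics, with Canis familiaris (Canis lupus familiaris) as the target (on this read-out higher numbers stand for fast clearance and lower numbers for slow clearance), the three measured compounds stand as follows.

Compound 1 `COc1ncc(C(=O)NC2(C(=O)N[C@H](C)c3ccc(-n4nc(Cl)c5ccccc54)cc3F)CC2)s1`: 1.7 mL/min/kg
Compound 2 `C[C@@H](NC(=O)C1(NC(=O)c2ccc(Br)nc2)CC1)c1ccc(-n2nc(Cl)c3ccccc32)cc1F`: 2.6 mL/min/kg
Compound 3 `C[C@@H](NC(=O)C1(NC(=O)c2cncs2)CC1)c1ccc(-n2nc(Cl)c3ccccc32)cc1F`: 1.1 mL/min/kg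

Compound 3 thus gives the lowest of the three numbers; the step of a 1.5-fold lower number from compound 1 to compound 3 (0.19 log units; within the scatter) stays within the scatter, while the step of a 2.4-fold lower number from compound 2 to compound 3 (0.37 log units; beyond the scatter) lies beyond it. Compound 4 `COc1cc(C(=O)NC2(C(=O)N[C@H](C)c3ccc(-n4nc(Cl)c5ccccc54)cc3F)CC2)on1` carries 3-methoxy-1,2-oxazol-5-yl in place of 1,3-thiazol-5-yl on a carbonyl carbon. Going by the values given here, the steps that bear on it are the two earlier swaps of the aryl group on the same carbonyl carbon, a 1.5-fold higher number from compound 1 to compound 2 (0.18 log units; within the scatter) and a 2.4-fold lower number from compound 2 to compound 3 (0.37 log units; beyond the scatter), and the methoxy change a 1.5-fold lower number from compound 1 to compound 3 (0.19 log units; within the scatter). Only one of these exceeded the scatter, and modestly, so compound 4 is expected to move no further than the scatter, a 1.5-fold higher number from compound 3 to compound 4 (0.16 log units; within the scatter). Compound 4 is therefore estimated at 1.6 mL/min/kg, between 0.8 mL/min/kg and 3.2 mL/min/kg.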

Compound 4, clearance: 1.3 mL/min/kg
For compound 4 the middle estimate is 1.2-fold (0.09 log units) above the measured one, within the range that was stated.
By their numbers in this assay, from the lowest: compounds 3, 4, 1 and 2 (each within the scatter of the next, the first and the last beyond it).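

In this assay, the 3-methoxy-1,2-oxazol-5-yl group on this carbonyl carbon, with its two oxygens and no sulfur, stays level with both 1,3-thiazol-5-yl-type groups, with a 1.2-fold higher number from compound 3 to compound 4 (0.07 log units; within the scatter) and a 1.3-fold lower number from compound 1 to compound 4 (0.12 log units; within the scatter). Even against the 6-bromopyridin-3-yl group, a 2.0-fold lower number from compound 2 to compound 4 (0.30 log units; within the scatter) stays within the scatter, so this position tolerates this change of five-membered ring without a clear shift in clearance. Nothing available explains this tolerance. The compounds shown leave open whether an amine, a carboxylic acid or a longer chain in place of the methoxy would shift clearance beyond the scatter.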